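This account rests on a few compounds, and the source may have more. Where it says the series, first, only, none or still open, it means among the compounds named here.

Compound 1, `CCOC(=O)C1=C(C)NC(C)=C(C(=O)OC)C1c1[nH]c(CC)nc1Cl`: 2.02 nM in an assay on ileum for inhibition of Voltage-dependent L-type calcium channel subunit alpha-1C (Cavia porcellus); a higher number here means a weaker inhibitor, a lower number a stronger inhibitor
Compound 2, `CCc1nc(Cl)c(C2C(C(=O)OC)=C(C)NC(C)=C2C(=O)OC(C)C)[nH]1`: 0.488 nM in this assay
Compound 3, `CCc1nc(Cl)c(C2C(C(=O)OC)=C(C)NC(C)=C2C(=O)OC(C)(C)C)[nH]1`: 50.8 nM in this assay

Compound 3 gives the highest number of the three. Its nearest neighbour is compound 1, and the step of a 25-fold higher number from compound 1 to compound 3 (1.40 log units; beyond the scatter); compound 2 is furthest, with a 100-fold higher number from compound 2 to compound 3 (2.02 log units; beyond the scatter). The smaller step within the set, a 4.1-fold lower number from compound 1 to compound 2 (0.62 log units; beyond the scatter), runs the other way.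

Compound 4, `CCc1nc(Cl)c(C2C(C(=O)OC)=C(C)NC(C)=C2C(=O)OCc2ccccc2)[nH]1`, has not been measured. It differs from compound 3 in one place: benzyl in place of tert-butyl on an oxygen next to a carbonyl group. Both large measured steps into compound 3 concern the arrival of the tert-butyl group on that same oxygen, and each made the number much higher; compound 4 removes that group again. Among the compounds with values here, no measured pair shows a benzyl group, so the account rests on the expectation that leaving tert-butyl behind reverses much of what a 25-fold higher number from compound 1 to compound 3 (1.40 log units; beyond the scatter) and a 100-fold higher number from compound 2 to compound 3 (2.02 log units; beyond the scatter) brought. Compound 4 is therefore expected to give a clearly lower number, a step of about a 17-fold lower number from compound 3 to compound 4 (1.23 log units; beyond the scatter). The estimate for compound 4 is 3 nM, with a range from 0.6 nM to 15 nM.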

Compound 4, half-maximal inhibitory concentration: 1.75 nM
Compound 4: middle estimate off by 1.7-fold (0.23 log units), on the high side; low and high end bracket the measured number.
By their numbers in this assay, from the lowest: compound 2; then compounds 4 and 1 (each within the scatter of the next); then compound 3.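

In this assay, the position on an oxygen next to a carbonyl group tolerates a group with a six-membered aromatic ring, and the change to benzyl gives a 29-fold lower number from compound 3 to compound 4 (1.46 log units; beyond the scatter) even though benzyl has 7 heavy atoms against 4 for tert-butyl, so among these groups a larger heavy-atom count does not go with a higher number. Benzyl and ethyl cannot be told apart here, with a 1.2-fold lower number from compound 1 to compound 4 (0.06 log units; within the scatter) while a 3.6-fold higher number from compound 2 to compound 4 (0.55 log units; beyond the scatter) leaves compound 2 with the lowest number of the four. No measurement on hand offers an explanation for these differences.

The compounds shown leave open how a longer chain ending in phenyl, or a chain carrying an amine, would read on this oxygen. They also leave open whether a chlorine or a methoxy group on the benzyl ring would shift the number.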